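Adding a Fluoro to the Phenyl of Compound 2

The source may hold more compounds than are shown below. What is called first, only, known or untested is meant among the compounds shown, and "the series" means these compounds.

Measured so far in a functional assay on MCF7 cells (Homo sapiens) for cytotoxicity, read by MTT assay, with a stated time of 72 h; a lower number here means a stronger inhibitor, a higher number a weaker inhibitor:
Compound 1, `O=C(NC/C=C\Cn1cc(F)c(=O)[nH]c1=O)c1ccccc1`: > 100000 nM
Compound 2, `Nc1ccn(C/C=C\CNC(=O)c2ccccc2)c(=O)n1`: 31400 nM

The value for compound 1 is a limit of the assay, not a number. Compound 2 is therefore the only compound with a real number in this assay; the other entry is a limit, as shown by the limit of > 100000 nM in this assay, at which 1 of the 2 values shown sits.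

Compound 3, `Nc1ccn(C/C=C\CNC(=O)c2ccc(F)cc2)c(=O)n1`, has not yet been measured. It differs from compound 2 by fluoro in place of hydrogen on an aromatic carbon. Among the measured compounds shown here, no step between two measured compounds is available to guide the size of such a change, so the expectation is a step no larger than the usual scatter, in no particular direction: for compound 3 the estimated step is a 1.0-fold lower number from compound 2 to compound 3 (0.02 log units; within the scatter). Compound 3 is thus expected to give 30000 nM, within a range from 10000 nM to 100000 nM.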

Compound 3, half-maximal inhibitory concentration: > 100000 nM
Compound 3: only a limit was reported; the forecaster's own chance of this, stated with the estimate: 25%; at least 3.3-fold (0.52 log units) between middle value and limit.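

In this assay, among the compounds shown here, the change from phenyl to 4-fluorophenyl gives an at least 3.1-fold higher number from compound 2 to compound 3 (0.50 log units; beyond the scatter), the first step that can be read at all. It shows that this place on the phenyl, para to a large group, is sensitive: replacing a hydrogen with a single fluorine atom is enough to move compound 3 toward a weaker inhibitor than compound 2. The value of compound 3 is a limit, so the step gives only a smallest size, and most of the series now sits at that same edge: the limit of > 100000 nM in this assay, at which 2 of the 3 values shown sit.

On these data alone, whether a chloro, a methoxy or an amine at this place would keep the activity of compound 2 stays open. So does whether fluoro elsewhere on the phenyl would have the same effect.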